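Hydrogen in place of methoxy: a step without measured precedent

The source may hold more compounds than are shown below. What is called first, only, known or untested is meant among the compounds shown, and "the series" means these compounds.

Going by the values given here, compound 1 `COc1ccc(/C=C2\CCC/C(=C\c3ccccc3[N+](=O)[O-])C2=O)cc1` is the only compound here with a numbered result: in a functional assay on CCRF-CEM cells (Homo sapiens) for cytotoxicity, with a stated time of 72 h (a lower number here means a stronger inhibitor, a higher number a weaker inhibitor), compound 1 gives 7450 nM. Compound 2 `CN(C)c1ccc(/C=C2\CCC/C(=C\c3ccc([N+](=O)[O-])cc3)C2=O)cc1` gives > 500000 nM, which is a limit of the assay and not a number, namely (the limit of > 500000 nM in this assay, at which 1 of the 2 values shown sits). Compound 3 `O=C1/C(=C/c2ccccc2)CCC/C1=C\c1ccccc1[N+](=O)[O-]` differs from compound 1 in one place, (hydrogen in place of methoxy on an aromatic carbon). Among the compounds with values here, no measured pair shows this change, so its size is unknown here. I expect this step to be a small loss, near the scatter or none beyond it, and the expected step is a 1.5-fold higher number from compound 1 to compound 3 (0.17 log units; within the scatter). Compound 3 is accordingly expected to give 11000 nM, within 3500 nM to 40000 nM.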

Compound 3, half-maximal inhibitory concentration in the CCRF-CEM assay: 925 nM
Estimate against measurement, compound 3: 12-fold (1.08 log units) above, and the stated range ends above it.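

In the CCRF-CEM assay the change from 4-methoxyphenyl to phenyl is a clear gain, an 8.1-fold lower number from compound 1 to compound 3 (0.91 log units; beyond the scatter), so this core does not need the methoxy at this place on the ring, and it does better without it. In a physicochemical assay for lipophilicity (a higher number here means a more lipophilic compound, a lower number a more polar compound), compound 1 gives 4.86 and compound 3 gives 4.86, so the two stand level on that scale. Nothing measured here accounts for the step in cytotoxicity.

From the compounds shown here alone, whether a smaller group at this place, such as a fluorine atom or a hydroxyl, would keep the gain stays open.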